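Working notes: amino replaced by hydrogen in compound 2

The compounds below may be only part of what the source reports. "The series", "measured", "known", "first", "only" and "open" are said of these compounds alone.

compound 1, `COc1ccc(/C=C/C(=O)c2cccc(Br)c2)cc1OC`: > 50000 nM
compound 2, `COc1ccc(/C=C/C(=O)c2ccc(N)c(-c3ccc(F)cc3)c2)cc1OC`: > 50000 nM

In an assay on A549 cells for inhibition of transcription factor p65 (Homo sapiens), read by fluorescence, with a stated time of 2 h (on this read-out higher numbers stand for weaker inhibition and lower numbers for stronger inhibition), compound 1 gives > 50000 nM, a limit of the assay and not a number. In this assay compound 2 likewise gives > 50000 nM, again only a limit. Compound 2 therefore stands at the limit of > 50000 nM in this assay, at which 2 of the 2 values shown sit; no ordering between the two values is possible. Compound 3, `COc1ccc(/C=C/C(=O)c2cccc(-c3ccc(F)cc3)c2)cc1OC`, differs from compound 2 by hydrogen in place of amino on an aromatic carbon. For the measured compounds named here, no measured step covers this change, and the expected step that the limit leaves unreadable from compound 2 to compound 3 is none beyond the scatter. Compound 3 is thus expected at 80000 nM, within 30000 nM to 200000 nM, most probably reported again as a limit.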

Compound 3, half-maximal inhibitory concentration: > 50000 nM
Compound 3: a limit, no number; the forecaster's own chance of this, stated with the estimate: 85%; the middle value is on the limit's open side.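

For the compounds shown here, compound 3 gives > 50000 nM, a limit and not a number, so no step from it to compound 1 or compound 2 can be read. The compounds shown leave open whether hydrogen in place of amino, or 4-fluorophenyl in place of bromo, changes inhibition at all.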